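Ethoxy to phenoxy on the shared core

The source may hold more compounds than are shown below. What is called first, only, known or untested is meant among the compounds shown, and "the series" means these compounds.

Three compounds of the series carry a measured value in a physicochemical assay for lipophilicity; on this read-out higher numbers stand for higher lipophilicity and lower numbers for lower lipophilicity. Compound 1 `CCOc1ccccc1C1=NC(c2ccccc2)CO1` gives 4.22 in this assay. Compound 2 `Clc1cccc(C2=NC(c3ccccc3)CO2)c1Cl` gives 4.28 in this assay, and compound 3 `Clc1ccc(C2=NC(c3ccccc3)CO2)c(Cl)c1` gives 4.4 in this assay. Both of these numbers fall within the scatter of the value of compound 1, so the three measured compounds cannot be told apart on this read-out and no order can be read among them. For the measured compounds named here, no pair of measured compounds differs in a single place, so no measured step is available to lean on.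

Compound 4 `c1ccc(Oc2ccccc2C2=NC(c3ccccc3)CO2)cc1` is not yet measured. Its relation to compound 1 is phenyl in place of ethyl on an oxygen on an aromatic ring. With no measured step of this kind in the set, the expectation rests on the change itself: a step well beyond the scatter, upward, of roughly a number 0.98 log units higher from compound 1 to compound 4 (beyond the scatter) in this assay is expected. Compound 4 is therefore estimated at 5.2 in this assay, with a range from 4.8 to 5.6.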

Compound 4, partition coefficient: 5.61
Estimate against measurement, compound 4: 0.41 log units below; the whole stated range lies below it.
By their numbers in this assay, from the lowest: compounds 1, 2 and 3 (each within the scatter of the next); then compound 4.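

Phenyl in place of ethyl on an oxygen on an aromatic ring gives the first step that can be read in this series, and it is large: a number 1.39 log units higher from compound 1 to compound 4 (beyond the scatter) in this assay. For the compounds shown here, no earlier pair differed in a single place, so this is the first direct evidence that the group on this oxygen can move the read-out well beyond the scatter. Nothing shown accounts for the size of this step.

Only ethyl and phenyl are shown on this oxygen, so it remains open whether the step follows the aromatic ring or the higher carbon count; a longer chain such as hexyl, or a cyclohexyl, on the same oxygen would separate the two. Also open, from the compounds shown here alone, is how far an amine or a carboxylic acid on the entering phenyl would change the value of compound 4.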